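A few compounds are considered here, and "the series" means these few. Any claim that something is new, unique, unknown or untested is made for them only; others in the source may bear on it.

In a functional assay on U-373MG ATCC cells (Homo sapiens) for inhibition, read by colorimetric assay and MTT assay, with a stated time of 72 h (on this read-out higher numbers stand for weaker inhibition and lower numbers for stronger inhibition), compound 1 `C=CCCCCOc1ccccc1-c1cnc(OCCCCC=C)n1C` gives 7000 nM and compound 2 `C=CCCCCOc1ncc(-c2ccccc2OC)n1C` gives 9000 nM. Among the compounds with values here, these are the only two numbers so far, and they lie within the scatter of each other, so compound 1 cannot be set apart from its single neighbour.

Compound 3 `C=CCCCCOc1ccccc1-c1cnc(OC)n1C` departs from compound 1 at one place: hydrogen in place of pent-4-en-1-yl on a saturated chain carbon bound to an oxygen on an aromatic ring. Hydrogen stands in place of pent-4-en-1-yl on a saturated chain carbon bound to an oxygen on an aromatic ring, which amounts to (hex-5-en-1-yl)oxy giving way to methoxy.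

Within the data shown here, only one measured step bears on this change: a 1.3-fold higher number from compound 1 to compound 2 (0.11 log units; within the scatter). It reads the same in words, but it is made at the other hex-5-en-1-yl chain of compound 1, so it offers guidance by analogy only. Among the measured compounds shown here, no measurement yet covers the change at the chain in question. On that single precedent, no shift beyond the scatter is expected in this assay.

The expected step is a 1.3-fold higher number from compound 1 to compound 3 (0.11 log units; within the scatter). For compound 3, the estimated value is 9000 nM, with an expected range of 4500 nM to 18000 nM.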

Compound 3, half-maximal inhibitory concentration: > 100000 nM
Compound 3 was reported as a limit; the forecaster's own chance of this, stated with the estimate: 10%; middle value at least 11-fold (1.04 log units) away from the limit.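

In this assay, the two hex-5-en-1-yl chains of the parent structure do not count alike: the same exchange for methyl gives a 1.3-fold higher number from compound 1 to compound 2 (0.11 log units; within the scatter) at one chain but an at least 14-fold higher number from compound 1 to compound 3 (1.15 log units; beyond the scatter) at the other. Compound 3 stands at a limit of the assay and not at a number, so this second step has no upper end: the limit of > 100000 nM in this assay, at which 1 of the 3 values shown sits. Compound 3 keeps one hex-5-en-1-yl chain, as compound 2 does, so among these three compounds a single such chain is not enough in itself, and which of the two chains remains decides the result.

The compounds shown leave open whether the whole hex-5-en-1-yl chain is needed at this place, or whether a shorter propyl chain, a saturated hexyl chain, or a chain ending in an amine or a carboxylic acid would serve as well, which would separate chain length from the terminal double bond. They also leave open whether the chain that compound 2 lacks could be replaced by anything else on the same oxygen.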